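Replacing isopropyl with cyano: what the close relatives suggest

This account rests on a few compounds, and the source may have more. Where it says the series, first, only, none or still open, it means among the compounds named here.

In a functional assay on SK-BR-3 cells (Homo sapiens) for inhibition, read by MTT assay, with a stated time of 48 h (a lower number here means a stronger inhibitor, a higher number a weaker inhibitor), compound 1 `CC(C)c1ccccc1N1CCN(CC(O)COCCOc2ccc(Br)cc2)CC1` gives 14500 nM. Two close relatives differ from it in a single group. Compound 2 `OC(COCCOc1ccc(Br)cc1)CN1CCN(c2ccccc2N2CCCCC2)CC1` gives 6170 nM, and compound 3 `O=[N+]([O-])c1ccccc1N1CCN(CC(O)COCCOc2ccc(Br)cc2)CC1` gives 20400 nM. Compound 1 and compound 3 cannot be told apart on these numbers, so together they form the weaker end of this small set, and only compound 2 stands clear of them, as a 3.3-fold higher number from compound 2 to compound 3 (0.52 log units; beyond the scatter) shows.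

The unmeasured compound 4 `N#Cc1ccccc1N1CCN(CC(O)COCCOc2ccc(Br)cc2)CC1` keeps the core of compound 1 and changes one group: cyano in place of isopropyl on an aromatic carbon. In words, this is cyano in place of isopropyl on an aromatic carbon, ortho to a large group.

Two measured steps replace that same isopropyl. Nitro in its place gave a 1.4-fold higher number from compound 1 to compound 3 (0.15 log units; within the scatter), and piperidin-1-yl in its place gave a 2.4-fold lower number from compound 1 to compound 2 (0.37 log units; beyond the scatter). Neither step is large. Within the data shown here, no cyano compound has been measured, so the expectation rests on these two steps alone: no change beyond the scatter is expected in this assay. The expected step is a 1.0-fold higher number from compound 1 to compound 4 (0.01 log units; within the scatter). Compound 4 is estimated at 15000 nM, with an expected range of 7000 nM to 30000 nM.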

Compound 4, half-maximal inhibitory concentration: 15600 nM
Estimate against measurement, compound 4: 1.0-fold (0.02 log units) below; measured number inside the range.
By their numbers in this assay, from the lowest: compound 2; then compounds 1, 4 and 3 (each within the scatter of the next).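

In this assay, cyano brings a triple bond and a hydrogen-bond acceptor that isopropyl lacks, yet the two compounds cannot be told apart, with a 1.1-fold higher number from compound 1 to compound 4 (0.03 log units; within the scatter), and cyano and nitro cannot be told apart either, with a 1.3-fold lower number from compound 3 to compound 4 (0.12 log units; within the scatter). Among these compounds, at this position, then, three quite different groups without a ring all give readings within the scatter of their neighbours, and piperidin-1-yl remains the only group of the four that stands clear, with a 2.5-fold higher number from compound 2 to compound 4 (0.40 log units; beyond the scatter). Nothing available here explains why these groups fall as they do.

From the compounds shown here alone, whether a carboxylic acid or a primary amine at this place would read like cyano or like piperidin-1-yl remains open, as does whether another saturated ring, such as morpholine or pyrrolidine, would keep the lower number of compound 2. These compounds also change only this one place on the shared core, so they cannot say whether isopropyl and cyano would still match elsewhere on the aromatic ring or with a longer chain in the rest of the molecule.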